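Swapping the amine at the chain end of compound 3

The source may report more compounds than this note shows. Statements on the series, on what has been measured and on what is new or still open speak of the compounds shown alone.

Measured so far, in a functional assay on U-937 cells (Homo sapiens) for cytotoxicity, read by WST assay, with a stated time of 72 h; a higher number here means a weaker inhibitor, a lower number a stronger inhibitor:
Compound 1 `COc1cc2c(Nc3nc4ccc(C(=O)Nc5c(C)cc(C)cc5C)cc4s3)ncnc2cc1OCCCN1CCC(C)CC1` gives 5600 nM.
Compound 2 `COc1cc2c(Nc3nc4ccc(C(=O)Nc5c(C)cccc5C)cc4s3)ncnc2cc1OCCCN1CCCC1` gives 18900 nM.
Compound 3 `CCN(CC)CCCOc1cc2ncnc(Nc3nc4ccc(C(=O)Nc5c(C)cccc5C)cc4s3)c2cc1OC` gives 23700 nM.

Compound 3 has the highest number of the three; it sits close to compound 2 and furthest from compound 1. Compound 4 `COc1cc2c(Nc3nc4ccc(C(=O)Nc5c(C)cccc5C)cc4s3)ncnc2cc1OCCCN1CCCCC1` differs from compound 3 in one place: piperidin-1-yl in place of diethylamino on a saturated chain carbon, three bonds along the chain from an oxygen on an aromatic ring. Going by the values given here, the one measured step that bears on this kind of swap is a 1.3-fold higher number from compound 2 to compound 3 (0.10 log units; within the scatter), where one ring amine gave way to diethylamino with no change beyond the scatter. Putting a ring amine back in is therefore expected to give, in this assay, a step of about a 1.3-fold lower number from compound 3 to compound 4 (0.12 log units; within the scatter), that is, none beyond the scatter. Compound 4 is estimated at 18000 nM, with a range from 7000 nM to 45000 nM.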

Compound 4, half-maximal inhibitory concentration: 14700 nM
Compound 4: the middle estimate sits 1.2-fold (0.09 log units) above what was measured; low and high end bracket the measured number.
By their numbers in this assay, from the lowest: compound 1; then compounds 4, 2 and 3 (each within the scatter of the next).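

Placing a six-membered ring amine at this chain end gives a 1.6-fold lower number from compound 3 to compound 4 (0.21 log units; within the scatter) in this assay, and enlarging the ring gives a 1.3-fold lower number from compound 2 to compound 4 (0.11 log units; within the scatter). Diethylamino, pyrrolidin-1-yl and piperidin-1-yl therefore cannot be told apart at this position in this assay, so neither the ring nor its size shows a measurable effect here. No measurement shown explains this result. Still open, as far as these compounds go, is whether an amine with a second ring hetero atom, such as morpholin-4-yl, or a longer chain would give a step beyond the scatter.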